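Removing One Chloro from a Dichlorophenyl Anilino Series

A few compounds are considered here, and "the series" means these few. Any claim that something is new, unique, unknown or untested is made for them only; others in the source may bear on it.

Measured compounds:
compound 1, `CN1CCN(CCCOc2cccc3nc(Nc4ccc(Cl)c(F)c4)ccc23)CC1`, 1740 nM
compound 2, `CN1CCN(CCCOc2cccc3nc(Nc4ccc(F)c(F)c4)ccc23)CC1`, 4100 nM
compound 3, `CN1CCN(CCCOc2cccc3nc(Nc4cc(Cl)cc(Cl)c4)ccc23)CC1`, 1720 nM

In a functional assay on cells (Panel CNS (Carcinoma cell lines), Homo sapiens) for inhibition, read by sulforhodamine B assay, with a stated time of 48 h (on this read-out higher numbers stand for weaker inhibition of growth and lower numbers for stronger inhibition of growth), compound 3 gives the lowest of the three numbers, yet its separation from compound 1 is small: a 1.0-fold lower number from compound 1 to compound 3 (0.01 log units; within the scatter). Against compound 2 the gap is clearer: a 2.4-fold lower number from compound 2 to compound 3 (0.38 log units; beyond the scatter). Compound 4, `CN1CCN(CCCOc2cccc3nc(Nc4cccc(Cl)c4)ccc23)CC1`, differs from compound 3 in one place: hydrogen in place of chloro on an aromatic carbon. For the measured compounds named here, no measured step removes a halogen outright; the nearest guide is a 2.4-fold higher number from compound 1 to compound 2 (0.37 log units; beyond the scatter), where exchanging one halogen for another moved the number modestly. Loss of a whole chloro is expected to cost about as much, toward a higher number, so for compound 4 a step of a 1.6-fold higher number from compound 3 to compound 4 (0.21 log units; within the scatter) is expected. Compound 4 is therefore estimated at 2800 nM, with a likely range from 1300 nM to 6000 nM.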

Compound 4, concentration for 50% growth inhibition: 1890 nM
The estimate for compound 4 lay 1.5-fold (0.17 log units) above the measured number; measured number inside the range.
By their numbers in this assay, from the lowest: compounds 3, 1 and 4 (each within the scatter of the next); then compound 2.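

In this assay, hydrogen can replace one chloro of the 3,5-dichlorophenyl group with no step beyond the scatter (a 1.1-fold higher number from compound 3 to compound 4 (0.04 log units; within the scatter)), so this second chloro is not required to keep the read-out. The 3-chlorophenyl group also stays level with the 4-chloro-3-fluorophenyl group (a 1.1-fold higher number from compound 1 to compound 4 (0.04 log units; within the scatter)). For the compounds shown here, it separates from the 3,4-difluorophenyl group (a 2.2-fold lower number from compound 2 to compound 4 (0.34 log units; beyond the scatter)), leaving compound 2, the only compound without a chloro, apart from the other three. The compounds shown leave open how an unsubstituted phenyl, or a methoxy or trifluoromethyl group at this place, would read. No measurement at hand accounts for these steps.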